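This account rests on a few compounds, and the source may have more. Where it says the series, first, only, none or still open, it means among the compounds named here.

Compound 1 `O=C(CCCN1C(=O)c2ccccc2C1=O)Nc1ccc(I)cc1` and compound 2 `O=C(CCCN1C(=O)c2ccccc2C1=O)Nc1ccc(Cl)cc1Cl` share one core and differ only in the group carried on an amide-type nitrogen. Among the compounds with values here, in a functional assay on the whole organism (strain albino) with Mus musculus as the target, with a stated time of 0.5 h (on this read-out lower numbers stand for an effect already at smaller amounts and higher numbers for an effect only at larger amounts of compound), compound 1 gives 100 mg/kg, the lowest of the two numbers measured so far, while in this assay compound 2 gives 300 mg/kg. Within the data shown here, the single measured step, a 3.0-fold higher number from compound 1 to compound 2 (0.48 log units; beyond the scatter), is modest but beyond the scatter.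

Compound 3 `O=C(CCCN1C(=O)c2ccccc2C1=O)Nc1ccc(Cl)cc1I` differs from compound 1 (a group of 8 heavy atoms (6 carbon, 1 chlorine, 1 iodine; one six-membered aromatic ring of carbon only) in place of a group of 7 heavy atoms (6 carbon, 1 iodine; one six-membered aromatic ring of carbon only), on an amide-type nitrogen). This change resembles the step from compound 1 to compound 2 in that a second halogen joins the ring on the amide-type nitrogen, though here one of the two halogens remains iodine. Because of a 3.0-fold higher number from compound 1 to compound 2 (0.48 log units; beyond the scatter), a higher number is expected for compound 3, of similar or somewhat smaller size, giving an expected step of a 2.0-fold higher number from compound 1 to compound 3 (0.30 log units; within the scatter). Compound 3 is therefore estimated at 200 mg/kg, within a range from 100 mg/kg to 400 mg/kg.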

Compound 3, minimum effective dose: 100 mg/kg
Compound 3: middle estimate off by 2.0-fold (0.30 log units), on the high side; the measured number falls inside the stated range.
By their numbers in this assay, from the lowest: compounds 1 and 3 (each within the scatter of the next); then compound 2.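

In this assay, a second halogen on the ring does not by itself raise the number, as the step of no change at the digits printed from compound 1 to compound 3 (within the scatter) shows. Iodo in place of chloro on an aromatic carbon gives a 3.0-fold lower number from compound 2 to compound 3 (0.48 log units; beyond the scatter), so among these three compounds the two that carry iodine, compound 1 and compound 3, sit together, and the compound with two chloro groups, compound 2, stands apart with the higher number. Nothing measured here explains this difference.

The compounds shown leave open whether bromo or methoxy in place of the iodo would keep the number where it is. They also leave open whether a plain phenyl ring, with no halogen at all, would do the same.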